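This account rests on a few compounds, and the source may have more. Where it says the series, first, only, none or still open, it means among the compounds named here.

Of the compounds shown here, two have been measured in an assay on cell membranes for displacement of a labelled ligand from corticotropin-releasing factor receptor 1 (Rattus norvegicus); on this read-out higher numbers stand for weaker inhibition and lower numbers for stronger inhibition. Compound 1 `CCCCN(C)c1nc(C)nc2c(-c3ccc(OC)nc3C)c(C)nn12` gives 8.1 nM in this assay. Compound 2 `CCC(CC)Nc1nc(C)nc2c(-c3cnc(N(C)C)cc3C)c(C)nn12` differs from compound 1 in several places. In this assay compound 2 gives 24.8 nM. Of these two numbers, compound 1 stands lower, and its gap to compound 2 lies beyond the usual scatter of repeated measurements. Compound 3 `CCC[C@H](C)Nc1nc(C)nc2c(-c3ccc(OC)nc3C)c(C)nn12` has not yet been measured. It keeps everything of compound 1 except one group: (1-methylbutyl)amino in place of butyl(methyl)amino on an aromatic carbon. The entering group brings a hydrogen-bond donor that the leaving group lacked, together with a defined stereocentre. For the measured compounds named here, no measured pair shows this same change, so its size can only be estimated. Compound 2, with its 24.8 nM, shows that an amine bearing one hydrogen can still give a low number. The step from compound 1 to compound 3 is expected to stay small, within the scatter, in either direction a 1.1-fold higher number from compound 1 to compound 3 (0.05 log units; within the scatter). Compound 3 is expected to give about 9 nM in this assay, with a likely range from 3 nM to 30 nM.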

Compound 3, half-maximal inhibitory concentration: 4.5 nM
Estimate against measurement, compound 3: 2.0-fold (0.30 log units) above; the range from low to high includes it.
By their numbers in this assay, from the lowest: compounds 3 and 1 (each within the scatter of the next); then compound 2.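

In this assay, placing (1-methylbutyl)amino instead of butyl(methyl)amino on this aromatic carbon between two ring nitrogen atoms gives a 1.8-fold lower number from compound 1 to compound 3 (0.26 log units; within the scatter) with the rest of compound 1 unchanged. For the compounds shown here, this is the first pair that differs in only one place, and it shows that this position tolerates this swap of two six-heavy-atom amino groups, even though the entering group adds a hydrogen-bond donor and a defined stereocentre. No measurement here explains why the two groups read so closely.

Going by these compounds, it remains open whether the opposite arrangement at the stereocentre, a shorter chain such as (1-methylethyl)amino, or a ring such as cyclopentylamino would fit this position equally well. On these data alone, compound 2 differs from compound 3 in several places, so the effect of its dimethylamino-bearing ring on this read-out also remains open.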